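Carbamate ester variation on the shared core

The compounds below may be only part of what the source reports. "The series", "measured", "known", "first", "only" and "open" are said of these compounds alone.

Compound 1 `CC(C)OC(=O)N1CCC(n2ncc3cc(-c4ccc(S(C)(=O)=O)cc4)ncc32)CC1` in a functional assay on HEK293 cells for agonist activity at Glucose-dependent insulinotropic receptor (Homo sapiens), read by cAMP accumulation, with a stated time of 30 min (a higher number here means that more compound is needed for the effect, a lower number that less compound is needed), gives 42 nM. Compound 2 `CC(C)(C)OC(=O)N1CCC(n2ncc3cc(-c4ccc(S(C)(=O)=O)cc4)ncc32)CC1` in this assay gives 20 nM.

Compound 2 stands at the lower of the two numbers, reached by a 2.1-fold lower number from compound 1 to compound 2 (0.32 log units; beyond the scatter). Compound 3 `CC(C)COC(=O)N1CCC(n2ncc3cc(-c4ccc(S(C)(=O)=O)cc4)ncc32)CC1` carries isobutyl in place of tert-butyl on an oxygen next to a carbonyl group. Going by the values given here, no measured step bears directly on this change; the only measured step, a 2.1-fold lower number from compound 1 to compound 2 (0.32 log units; beyond the scatter), concerns a different group on the same oxygen and was modest. In this assay a step of at most comparable size in either direction, or none beyond the scatter, is expected. Compound 3 is estimated at 30 nM, between 12 nM and 80 nM. The expected step is a 1.5-fold higher number from compound 2 to compound 3 (0.18 log units; within the scatter).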

Compound 3, half-maximal effective concentration: 11 nM
Compound 3: middle estimate off by 2.7-fold (0.44 log units), on the high side, and the stated range ends above it.
By their numbers in this assay, from the lowest: compounds 3 and 2 (each within the scatter of the next); then compound 1.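

Isobutyl in place of tert-butyl on an oxygen next to a carbonyl group gives a 1.8-fold lower number from compound 2 to compound 3 (0.26 log units; within the scatter), so this assay does not separate these two groups. Isobutyl in place of isopropyl gives a 3.8-fold lower number from compound 1 to compound 3 (0.58 log units; beyond the scatter), so both isobutyl and tert-butyl are accepted on this oxygen, while isopropyl stands beyond the scatter from each. No evidence at hand accounts for these differences.

Going by these compounds, whether a longer chain, such as n-pentyl, or a benzyl group on this oxygen keeps the number in this range remains open. Also open, on these data alone, is how an amide or urea nitrogen in place of this oxygen would read.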